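A few compounds are considered here, and "the series" means these few. Any claim that something is new, unique, unknown or untested is made for them only; others in the source may bear on it.

Measured compounds in a functional assay on HCT-116 cells (Homo sapiens) for cytotoxicity, read by MTT assay, with a stated time of 72 h; a lower number here means a stronger inhibitor, a higher number a weaker inhibitor:
- compound 1, `CN1[C@@H]2c3[nH]c4ccccc4c3C[C@H]1[C@H](C#N)N1[C@@H](CNC(=O)c3ccc(F)cc3)c3[nH]c4ccccc4c3C[C@@H]21`: 140 nM
- compound 2, `CN1[C@@H]2c3[nH]c4ccccc4c3C[C@H]1[C@H](C#N)N1[C@@H](CNC(=O)c3ccc4ccccc4c3)c3[nH]c4ccccc4c3C[C@@H]21`: 420 nM
- compound 3, `CN1[C@@H]2c3[nH]c4ccccc4c3C[C@H]1[C@H](C#N)N1[C@@H](CNC(=O)c3cc4ccccc4s3)c3[nH]c4ccccc4c3C[C@@H]21`: 500 nM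

Compound 3 gives the highest number of the three in this assay. Its nearest neighbour is compound 2, separated by a 1.2-fold higher number from compound 2 to compound 3 (0.08 log units; within the scatter), which is within the scatter; its furthest is compound 1, separated by a 3.6-fold higher number from compound 1 to compound 3 (0.55 log units; beyond the scatter), which is beyond it.

Compound 4, `CN1[C@@H]2c3[nH]c4ccccc4c3C[C@H]1[C@H](C#N)N1[C@@H](CNC(=O)/C=C/c3ccccc3)c3[nH]c4ccccc4c3C[C@@H]21`, differs from compound 3 at one place: 2-phenylethenyl in place of 1-benzothiophen-2-yl on a carbonyl carbon.

Within the data shown here, three measured steps concern the same position. Steps a 3.0-fold higher number from compound 1 to compound 2 (0.48 log units; beyond the scatter) and a 3.6-fold higher number from compound 1 to compound 3 (0.55 log units; beyond the scatter) show a modest rise in the number when the 4-fluorophenyl of compound 1 is replaced by a two-ring group. Step a 1.2-fold higher number from compound 2 to compound 3 (0.08 log units; within the scatter), between two two-ring groups, is within the scatter. Among the measured compounds shown here, no measured step involves a 2-phenylethenyl group or any group with a double bond outside aromatic rings. Returning to a group with a single six-membered aromatic ring, as in compound 1, points towards a lower number than compound 3, but the new group is not the one measured in compound 1, so the expected step is small and uncertain. For compound 4 the expected step is a 1.7-fold lower number from compound 3 to compound 4 (0.22 log units; within the scatter). Compound 4 is estimated at 300 nM, within 120 nM to 800 nM.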

Compound 4, half-maximal inhibitory concentration: 1960 nM
The estimate for compound 4 lay 6.5-fold (0.82 log units) below the measured number; the whole stated range lies below it.
By their numbers in this assay, from the lowest: compound 1; then compounds 2 and 3 (each within the scatter of the next); then compound 4.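

In this assay the number of aromatic rings alone does not order this position: 2-phenylethenyl carries one six-membered aromatic ring, as 4-fluorophenyl does, yet the change gives a 14-fold higher number from compound 1 to compound 4 (1.15 log units; beyond the scatter) and is the largest step in the series. The two-ring groups also give lower numbers than 2-phenylethenyl, with a 3.9-fold higher number from compound 3 to compound 4 (0.59 log units; beyond the scatter) and a 4.7-fold higher number from compound 2 to compound 4 (0.67 log units; beyond the scatter) on the same carbonyl carbon. The order at this position now runs from 4-fluorophenyl through the two-ring groups to 2-phenylethenyl, but nothing available accounts for that order.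

Going by these compounds, whether the rise follows the double bond or the longer link to the ring remains open, and a 2-phenylethyl group on the same carbonyl carbon would bear on that. A plain phenyl group would show how much of the low number of compound 1 depends on its fluorine.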